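Cytotoxicity of threonine-derived amides with varied aromatic caps

The source may hold more compounds than are shown below. What is called first, only, known or untested is meant among the compounds shown, and "the series" means these compounds.

Measured compounds:
- compound 1 `CCCCCCCCCCCCCCNC(=O)[C@@H](NC(=O)c1ccco1)[C@@H](C)O`: > 400000 nM
- compound 2 `CCCCCCCCCCCCCCNC(=O)[C@@H](NC(=O)c1cccs1)[C@@H](C)O`: 88400 nM
- compound 3 `CCCCCCCCCCCCCCNC(=O)[C@@H](NC(=O)c1nccc2ccccc12)[C@@H](C)O`: 28600 nM

In a functional assay on HepG2 cells (Homo sapiens) for cytotoxicity, read by MTT assay, with a stated time of 48 h (on this read-out higher numbers stand for weaker inhibition and lower numbers for stronger inhibition), compound 1 gives only a limit, > 400000 nM. In this assay compound 2 gives 88400 nM, and compound 3 gives 28600 nM, the lowest number among the three. The bicyclic cap of compound 3 improved on the thiophene of compound 2 by a 3.1-fold lower number from compound 2 to compound 3 (0.49 log units; beyond the scatter) and on the furan of compound 1 by an at least 13-fold lower number from compound 1 to compound 3 (1.14 log units; beyond the scatter).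

Compound 4 `CCCCCCCCCCCCCCNC(=O)[C@@H](NC(=O)c1cc2ccccc2n1C)[C@@H](C)O` keeps the shared core and swaps the cap: 1-methyl-1H-indol-2-yl in place of isoquinolin-1-yl on a carbonyl carbon. The new cap is again bicyclic but its attachment ring is five-membered, as in compounds 1 and 2. In this assay compound 4 is therefore expected near compound 3, with a step of a 1.4-fold higher number from compound 3 to compound 4 (0.15 log units; within the scatter) anticipated, inside the usual scatter. The estimate for compound 4 is 40000 nM, expected between 12000 nM and 130000 nM.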

Compound 4, half-maximal inhibitory concentration: 34500 nM
Compound 4: the middle estimate sits 1.2-fold (0.06 log units) above what was measured, within the range that was stated.
By their numbers in this assay, from the lowest: compounds 3 and 4 (each within the scatter of the next); then compound 2. At a limit, above all of these: compound 1.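

In this assay the 1-methyl-1H-indol-2-yl cap and the isoquinolin-1-yl cap cannot be told apart (a 1.2-fold higher number from compound 3 to compound 4 (0.08 log units; within the scatter)), which is within the scatter, so a cap with a five-membered aromatic ring can read like one built only from six-membered rings. The advantage over the thiophen-2-yl cap (a 2.6-fold lower number from compound 2 to compound 4 (0.41 log units; beyond the scatter)) and the furan-2-yl cap (an at least 11-fold lower number from compound 1 to compound 4 (1.06 log units; beyond the scatter)) therefore now holds for two bicyclic caps, not one. The furan-2-yl comparison rests on a limit rather than a number: the limit of > 400000 nM in this assay, at which 1 of the 4 values shown sits.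

Still open, on these data alone, is how a 1H-indol-2-yl cap lacking the methyl group would read here, and whether an all-carbon naphthalen-2-yl cap would read the same.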